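This account rests on a few compounds, and the source may have more. Where it says the series, first, only, none or still open, it means among the compounds named here.

Going by the values given here, in a functional assay for inhibition, with Rattus norvegicus as the target (a lower number here means a stronger inhibitor, a higher number a weaker inhibitor), compound 2 (`CCCCc1cc(OC)c2ccccc2c1OC(C)=O`) gives 440 nM as the highest number so far, with compound 1 (`CCCCc1c(C)c(OC)c2ccccc2c1OC(C)=O`) at 200 nM as its only neighbour. Compound 3 (`CCCCc1cc(OC)c2ccccc2c1O`) differs from compound 2 by acetoxy to hydroxy (hydrogen in place of acetyl on an oxygen on an aromatic ring), hydrogen in place of acetyl on an oxygen on an aromatic ring. Among the compounds with values here, the single measured step (a 2.2-fold higher number from compound 1 to compound 2 (0.34 log units; beyond the scatter)) is modest and concerns a different change, hydrogen in place of methyl on an aromatic carbon. It sets no direction, so no shift beyond the scatter is expected in this assay for this change. The expected step (a 1.1-fold lower number from compound 2 to compound 3 (0.04 log units; within the scatter)) is therefore small, with wide uncertainty. Compound 3 is estimated at 400 nM within a range of 130 nM to 1300 nM as a first expectation.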

Compound 3, half-maximal inhibitory concentration: 1470 nM
Beside the measured number, compound 3's estimate is 3.7-fold (0.57 log units) below it; the measured number lies above the stated range.
By their numbers in this assay, from the lowest: compound 1; then compound 2; then compound 3.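

In this assay the change from acetoxy to hydroxy on this oxygen gives a 3.3-fold higher number from compound 2 to compound 3 (0.52 log units; beyond the scatter) and so shows that the group on the oxygen, not only the methyl on the aromatic carbon, moves the number. Within this pair, the acetyl form holds the lower number. Nothing at hand explains this step.

The compounds shown leave open whether a propionyl group or a methyl ether on this oxygen would keep the lower number. Also open, going by these compounds, is whether the effects of the acetyl and of the methyl on the aromatic carbon add up.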